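Acyl swap on the hydroxy-methoxybenzyl anilide series

A few compounds are considered here, and "the series" means these few. Any claim that something is new, unique, unknown or untested is made for them only; others in the source may bear on it.

Compound 1 `COc1ccc(CN(C(=O)CCl)c2cc(OC)c(OC)c(OC)c2)cc1O` gives 250 nM in a functional assay on HCT-116 cells (Homo sapiens) for inhibition, read by MTT assay, with a stated time of 48 h (a higher number here means a weaker inhibitor, a lower number a stronger inhibitor), the smallest number among the three measured, though compound 3 `C/C=C/C(=O)N(Cc1ccc(OC)c(N)c1)c1cc(OC)c(OC)c(OC)c1` with 300 nM sits within the scatter of it. Among the compounds with values here, compound 2 `C/C=C/C(=O)N(Cc1ccc(OC)c(Br)c1)c1cc(OC)c(OC)c(OC)c1` gives 2800 nM; the only measured step, a 9.3-fold lower number from compound 2 to compound 3 (0.97 log units; beyond the scatter), concerns a substituent on an aromatic carbon, not the carbonyl carbon. Compound 4 `C/C=C/C(=O)N(Cc1ccc(OC)c(O)c1)c1cc(OC)c(OC)c(OC)c1` differs from compound 1 by prop-1-en-1-yl in place of chloromethyl on a carbonyl carbon. Within the data shown here, no measured step bears on this change; compound 3, which carries the (prop-1-en-1-yl)carbonyl, merely shows that this acyl group is compatible with numbers near compound 1. A step within the scatter, of uncertain direction, is therefore expected, and compound 4 is estimated at 350 nM (range 120 nM to 1200 nM), meaning a 1.4-fold higher number from compound 1 to compound 4 (0.15 log units; within the scatter).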

Compound 4, half-maximal inhibitory concentration: 55 nM
Estimate against measurement, compound 4: 6.4-fold (0.80 log units) above; the measured number lies below the stated range.
By their numbers in this assay, from the lowest: compound 4; then compounds 1 and 3 (each within the scatter of the next); then compound 2.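

In this assay the acyl group proves to matter: prop-1-en-1-yl in place of chloromethyl on a carbonyl carbon gives a 4.5-fold lower number from compound 1 to compound 4 (0.66 log units; beyond the scatter) so chloromethyl is not required for the lowest number in the series. With the (prop-1-en-1-yl)carbonyl held constant, hydroxy in place of amino gives a 5.5-fold lower number from compound 3 to compound 4 (0.74 log units; beyond the scatter) and hydroxy in place of bromo gives a 51-fold lower number from compound 2 to compound 4 (1.71 log units; beyond the scatter) placing hydroxy first among the three aromatic substituents. Nothing available explains these steps.

Longer chains on the carbonyl carbon remain open. So do a carboxylic acid or a methylamino group on the aromatic carbon.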